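Difluoromethoxy in place of pentafluorosulfanyl on the shared core

The source may hold more compounds than are shown below. What is called first, only, known or untested is meant among the compounds shown, and "the series" means these compounds.

Three compounds on the shared core have numbers in an assay on mitochondria from L6 cells (Rattus norvegicus) for activation, with a stated time of 90 min; a lower number here means that less compound is needed, a higher number that more compound is needed for the effect. Compound 2 `Oc1nc2nonc2nc1Nc1ccc(S(F)(F)(F)(F)F)cc1` gives 3900 nM, the lowest of the three. Compound 1 `Oc1nc2nonc2nc1Nc1ccc(OCC(F)(F)F)c(F)c1` gives 10400 nM, and compound 3 `Cc1cc(C)c(Nc2nc3nonc3nc2O)c(C)c1` gives 113000 nM; both gaps to compound 2 lie beyond the usual scatter. Compound 4 `Oc1nc2nonc2nc1Nc1ccc(OC(F)F)cc1` is not yet measured. It differs from compound 2 in one place: a group of 4 heavy atoms (1 carbon, 1 oxygen, 2 fluorine; no ring) in place of a group of 6 heavy atoms (5 fluorine, 1 sulfur; no ring), on an aromatic carbon. For the measured compounds named here, no measured pair shows this exact change, so the expected step rests on the spread seen across compounds 1, 2 and 3. A modest rise in the number, beyond the scatter, is expected, giving a step of a 2.6-fold higher number from compound 2 to compound 4 (0.41 log units; beyond the scatter). Compound 4 is therefore estimated at 10000 nM, within a range of 3500 nM to 30000 nM.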

Compound 4, half-maximal effective concentration: 20600 nM
The estimate for compound 4 lay 2.1-fold (0.31 log units) below the measured number; low and high end bracket the measured number.
By their numbers in this assay, from the lowest: compound 2; then compounds 1 and 4 (each within the scatter of the next); then compound 3.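

In this assay the aromatic carbon para to a large group proves sensitive to what it carries: difluoromethoxy in place of pentafluorosulfanyl gives a 5.3-fold higher number from compound 2 to compound 4 (0.72 log units; beyond the scatter) and this lies beyond the scatter. For the compounds shown here, this pair is the only one-place comparison, as compounds 1, 2 and 3 offered none. Nothing at hand accounts for the size of this step.

From the compounds shown here alone, whether trifluoromethyl or an amine here would sit nearer compound 2 or compound 4 stays open. Also open, going by these compounds, is whether the step would hold with other groups elsewhere on this ring.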